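From Chloro to Fluoro: What Compound 3 May Show

The source may report more compounds than this note shows. Statements on the series, on what has been measured and on what is new or still open speak of the compounds shown alone.

Compound 1 `CNc1cc(-c2ccccc2Cl)nc2c(Br)cnn12`: 1800 nM
Compound 2 `Clc1ccccc1-c1cc(NCOc2cccnc2)n2ncc(Br)c2n1`: 170 nM

In a functional assay on cells (Homo sapiens), read by thymidine incorporation (on this read-out lower numbers stand for stronger inhibition and higher numbers for weaker inhibition), compound 2 holds the lower of the two numbers, at 170 nM. Compound 3 `Fc1ccccc1-c1cc(NCOc2cccnc2)n2ncc(Br)c2n1` differs from it in one place: fluoro in place of chloro on an aromatic carbon. This is fluoro in place of chloro on an aromatic carbon, ortho to a large group, turning 2-chlorophenyl into 2-fluorophenyl.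

Going by the values given here, the only measured step, an 11-fold lower number from compound 1 to compound 2 (1.02 log units; beyond the scatter), is large, but it comes from (pyridin-3-yl)oxy in place of hydrogen at a different place. Among the compounds with values here, it shows that the numbers in this assay can move, yet no measured step covers the chloro-to-fluoro change. Compound 2 at 170 nM is therefore the best anchor, and no step beyond the scatter is expected. The estimated step is a 1.3-fold higher number from compound 2 to compound 3 (0.11 log units; within the scatter). For compound 3 the expected value is 220 nM, with an expected range from 80 nM to 600 nM.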

Compound 3, half-maximal inhibitory concentration: 210 nM
Beside the measured number, compound 3's estimate is 1.0-fold (0.02 log units) above it; the range from low to high includes it.
By their numbers in this assay, from the lowest: compounds 2 and 3 (each within the scatter of the next); then compound 1.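

In this assay, the fluoro-for-chloro exchange on the 2-chlorophenyl ring reads as a step within the scatter (a 1.2-fold higher number from compound 2 to compound 3 (0.09 log units; within the scatter)), so this read-out does not separate compound 2 from compound 3. Compound 1 and compound 2 both carry chloro here, so they could say nothing about this position; the pair now shows that, at this aromatic carbon, ortho to a large group, chloro and fluoro give numbers that cannot be told apart. Nothing available here explains this result.

The compounds shown leave open whether a bigger group at this same carbon, such as methoxy or trifluoromethyl, would move the number beyond the scatter. They also leave open what an amine or a nitrile would do there.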